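Chain extension on the alkoxy side of the triazole series

This account rests on a few compounds, and the source may have more. Where it says the series, first, only, none or still open, it means among the compounds named here.

Within the data shown here, compound 3 `CCCCOc1ccc(-n2cnnc2CC)cc1` is one of the three measured members. In a functional assay on the whole organism (strain C57B/6) with Mus musculus as the target, in the maximal electroshock model (on this read-out higher numbers stand for an effect only at larger amounts of compound and lower numbers for an effect already at smaller amounts), compound 3 gives only a limit, > 100 mg/kg. Compound 2 `CCOc1ccc(-n2cnnc2CC)cc1` likewise gives only a limit in this assay, > 100 mg/kg. Compound 1 `CCc1nncn1-c1ccc(OCc2ccccc2F)cc1` gives 21.2 mg/kg in this assay. The steps of an at least 4.7-fold higher number from compound 1 to compound 2 (0.67 log units; beyond the scatter) and an at least 4.7-fold higher number from compound 1 to compound 3 (0.67 log units; beyond the scatter) show that the smaller alkoxy chains sit at the limit, while the step that the two limits leave unreadable from compound 2 to compound 3 cannot be read, because of the limit of > 100 mg/kg in this assay, at which 2 of the 3 values shown sit.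

Compound 4 `CCCCCCCOc1ccc(-n2cnnc2CC)cc1` differs from compound 3 by propyl in place of hydrogen on a saturated chain carbon, four bonds along the chain from an oxygen on an aromatic ring, in words: propyl in place of hydrogen on a saturated chain carbon, four bonds along the chain from an oxygen on an aromatic ring. Among the measured compounds shown here, the only measured step of the same kind, the chain extension from compound 2 to compound 3, is unreadable, and the two steps from compound 1 point away from alkyl chains. No readable step beyond the scatter therefore supports a direction, and compound 4 is expected to stay near the limit, with an estimated step that the limit leaves unreadable from compound 3 to compound 4. The estimate for compound 4 in this assay is 110 mg/kg, within 40 mg/kg to 300 mg/kg.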

Compound 4, dose for half-maximal effect: 8.3 mg/kg
Compound 4: the middle estimate sits 13-fold (1.12 log units) above what was measured, outside the stated range (below it).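

In this assay, propyl in place of hydrogen, four bonds along the chain from the oxygen, gives the first readable effect of chain extension in this series: an at least 12-fold lower number from compound 3 to compound 4 (1.08 log units; beyond the scatter), and, against the shorter chain of compound 2, an at least 12-fold lower number from compound 2 to compound 4 (1.08 log units; beyond the scatter). An alkyl chain can thus carry the effect without the 2-fluorophenyl group, as hexyl in its place gives a 2.6-fold lower number from compound 1 to compound 4 (0.41 log units; beyond the scatter), although the shorter chains of compound 2 and compound 3 go against any general gain from alkyl chains. The two steps from the shorter chains give minimum sizes only, because each starts from a limit: the limit of > 100 mg/kg in this assay, at which 2 of the 4 values shown sit.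

Going by these compounds, the step between compound 2 and compound 3 cannot be read, so the chain length at which the effect sets in stays open. On these data alone, whether a longer chain than that of compound 4 gives a further change, or an amine on the chain keeps the effect, also stays open.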